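A few compounds are considered here, and "the series" means these few. Any claim that something is new, unique, unknown or untested is made for them only; others in the source may bear on it.

In a functional assay (muscle tissue) with Rattus norvegicus as the target (on this read-out lower numbers stand for an effect already at smaller amounts and higher numbers for an effect only at larger amounts of compound), compound 1 `CCNC(=O)C1=CC(C)(C)Oc2ccc([N+](=O)[O-])cc21` gives 4.57 nM, while compound 2 `CCCCNC(=O)C1=CC(C)(C)Oc2ccc([N+](=O)[O-])cc21` gives 21.9 nM, the higher of the two numbers. Compound 3 `CC(C)NC(=O)C1=CC(C)(C)Oc2ccc([N+](=O)[O-])cc21` is still unmeasured. Its difference from compound 2 is isopropyl in place of butyl on an amide-type nitrogen, with isopropyl in place of butyl on an amide-type nitrogen. Going by the values given here, only one measured step bears on this change: a 4.8-fold higher number from compound 1 to compound 2 (0.68 log units; beyond the scatter), a modest step. A modest move back towards a lower number is therefore expected in this assay, though a single step is thin support. The expected step is a 2.7-fold lower number from compound 2 to compound 3 (0.44 log units; beyond the scatter). For compound 3 the estimate is 8 nM, with an expected range from 3 nM to 22 nM.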

Compound 3, half-maximal effective concentration: 186 nM
For compound 3 the middle estimate is 23-fold (1.37 log units) below the measured one, and the stated range ends below it.
By their numbers in this assay, from the lowest: compound 1; then compound 2; then compound 3.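

In this assay the order at this position does not follow heavy-atom count: with 3 heavy atoms against 4 for butyl, isopropyl gives an 8.5-fold higher number from compound 2 to compound 3 (0.93 log units; beyond the scatter) and does not fall back towards the ethyl compound. Methyl in place of hydrogen on the saturated chain carbon bound to an amide-type nitrogen brings a 41-fold higher number from compound 1 to compound 3 (1.61 log units; beyond the scatter) and is the largest step shown. Nothing at hand accounts for this result. From the compounds shown here alone, whether tert-butyl or cyclopropyl on this nitrogen would follow isopropyl stays open, as does how a methyl or a longer chain such as hexyl would read.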